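From isopropylcarbamoyl to carbamoyl in compound 4

The source may report more compounds than this note shows. Statements on the series, on what has been measured and on what is new or still open speak of the compounds shown alone.

Measured in a functional assay on HeLa cells (Homo sapiens) for antiproliferative activity, read by CCK-8 assay, with a stated time of 72 h (on this read-out higher numbers stand for weaker inhibition of growth and lower numbers for stronger inhibition of growth), so far:
- compound 1 `CCC1C(=O)N(C)c2cnc(Nc3ccc(S(=O)(=O)NC)cc3)nc2N1c1ccn(C)n1` gives 2200 nM
- compound 2 `CCC1C(=O)N(C)c2cnc(-n3ccc4cc(C(=O)NC(C)C)ccc43)nc2N1c1ccn(C)n1` gives 4350 nM
- compound 3 `CC[C@@H]1C(=O)N(C)c2cnc(Nc3ccc(S(=O)(=O)NCCO)cc3)nc2N1C1CCCC1` gives 459 nM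

Compound 2 sits at the upper end of these numbers, within the scatter of compound 1 and beyond the scatter of compound 3. Compound 4 `CCC1C(=O)N(C)c2cnc(-n3ccc4cc(C(N)=O)ccc43)nc2N1c1ccn(C)n1` has hydrogen in place of isopropyl on an amide-type nitrogen and is otherwise unchanged. Within the data shown here, no measured pair of compounds shows this change. In this assay no step beyond the scatter is expected, and no firm direction can be given. The estimated change is a 1.1-fold lower number from compound 2 to compound 4 (0.06 log units; within the scatter) and would stay within the scatter. The expected value for compound 4 is 3800 nM, with an estimated range from 1300 nM to 11000 nM.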

Compound 4, concentration for 50% growth inhibition: 27400 nM
Estimate against measurement, compound 4: 7.2-fold (0.86 log units) below, outside the stated range (above it).
By their numbers in this assay, from the lowest: compound 3; then compounds 1 and 2 (each within the scatter of the next); then compound 4.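

In this assay, the amide-type nitrogen is not a neutral place in this series: isopropyl to hydrogen gives a 6.3-fold higher number from compound 2 to compound 4 (0.80 log units; beyond the scatter) and so weaker inhibition of growth, the first single-place step seen here. Compound 2 therefore keeps its number only with the isopropyl present, and the plain carbamoyl is clearly the poorer of the two groups. Nothing available accounts for this loss. Open, on these data alone, is whether methyl or ethyl on that nitrogen is already enough to match compound 2. Also open, as far as these compounds go, is how a longer chain or a cyclopentyl group would read there.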